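The compounds below may be only part of what the source reports. "The series", "measured", "known", "first", "only" and "open" are said of these compounds alone.

Measured so far in a functional assay on DU-145 cells (Homo sapiens) for inhibition, read by trypan blue exclusion, with a stated time of 96 h; a lower number here means a stronger inhibitor of growth, a higher number a weaker inhibitor of growth: compound 1 `Cc1ccsc1/C=C(/SCc1ccccc1F)C(=O)c1ccc(Cl)cc1` gives 50000 nM; compound 2 `Cc1ccc(CS/C(=C/c2sccc2C)C(=O)c2ccc(Cl)cc2)cc1` gives 10000 nM; compound 3 `COc1ccccc1/C=C(/SCc1ccc(C)cc1)C(=O)c1ccc(Cl)cc1` gives 10000 nM.

Compound 1 and compound 2 share a core and differ by 2-fluorophenyl in place of 4-methylphenyl on a saturated chain carbon bound to a sulfur, a change that produced a 5.0-fold higher number from compound 2 to compound 1 (0.70 log units; beyond the scatter). The cores of compound 2 and compound 3 differ by 2-methoxyphenyl in place of 3-methylthiophen-2-yl on a double-bonded chain carbon bound to a double-bonded chain carbon, and that exchange gave no change at the digits printed from compound 2 to compound 3 (within the scatter), so compound 2 and compound 3 stand level in this assay.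

Compound 4 `COc1ccccc1/C=C(/SCc1ccccc1F)C(=O)c1ccc(Cl)cc1` has not been measured. It differs from compound 3 by 2-fluorophenyl in place of 4-methylphenyl on a saturated chain carbon bound to a sulfur, the same change made at the same place as between compound 2 and compound 1. The expectation for compound 4 rests on the earlier change having produced a 5.0-fold higher number from compound 2 to compound 1 (0.70 log units; beyond the scatter). The step expected in this assay is therefore a 5.0-fold higher number from compound 3 to compound 4 (0.70 log units; beyond the scatter). Compound 4 is expected to come in near 50000 nM, within 15000 nM to 150000 nM.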

Compound 4, concentration for 50% growth inhibition: 10000 nM
Compound 4: middle estimate off by 5.0-fold (0.70 log units), on the high side, outside the stated range (below it).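

Put on the second core, 2-fluorophenyl in place of 4-methylphenyl gave no change at the digits printed from compound 3 to compound 4 (within the scatter) in this assay, so the change did not carry from one core to the other with the same size: the same change on two cores in this assay, a 5.0-fold higher number (0.70 log units; beyond the scatter) from compound 2 to compound 1 and no change at the digits printed (within the scatter) from compound 3 to compound 4, 5.0-fold (0.70 log units) apart, beyond the scatter of two such steps. With 2-fluorophenyl on the saturated chain carbon bound to a sulfur, 2-methoxyphenyl in place of 3-methylthiophen-2-yl gave a 5.0-fold lower number from compound 1 to compound 4 (0.70 log units; beyond the scatter), so that exchange also depends on its partner: the same change on two cores in this assay, no change at the digits printed (within the scatter) from compound 2 to compound 3 and a 5.0-fold lower number (0.70 log units; beyond the scatter) from compound 1 to compound 4, 5.0-fold (0.70 log units) apart, beyond the scatter of two such steps. These four compounds show that the two changes do not add independently here, but they do not show why, and one pair per core gives no rule for any further core.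

Going by these compounds, whether an unsubstituted phenyl on that chain carbon would follow compound 3 or compound 1 remains open. So does the outcome with an amine or a carboxylic acid at that place.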